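The source may report more compounds than this note shows. Statements on the series, on what has been measured and on what is new or still open speak of the compounds shown alone.

The three measured compounds in an assay for inhibition of hexokinase-2 (Homo sapiens), read by coupled enzyme assay, with a stated time of 10 min, in the presence of a further agent that is not named here (a higher number here means a weaker inhibitor, a lower number a stronger inhibitor), are these.
Compound 1 `C=C1CC[C@H]2[C@@](C)(CCC(=O)N[C@@]2(C)COC(=O)CCCC[C@@H]2CCSS2)[C@@H]1/C=C/C1=CCOC1=O` gives 9360 nM.
Compound 2 `C=C1CC[C@H]2[C@@](C)(CC[C@@H](OC(=O)c3ccccc3)[C@@]2(C)NC=O)[C@@H]1/C=C/C1=CCOC1=O` reaches only a limit of the assay, > 50000 nM.
Compound 3 `C=C1CC[C@H]2[C@@](C)(CC[C@@H](OC(=O)c3ccc([N+](=O)[O-])cc3)[C@@]2(C)NC=O)[C@@H]1/C=C/C1=CCOC1=O` likewise reaches only a limit of the assay, > 50000 nM.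

Among the measured compounds shown here, compound 3 thus stands not at a number but at the limit described by the limit of > 50000 nM in this assay, at which 2 of the 3 values shown sit, and the one step that involves it, a step that the two limits leave unreadable from compound 2 to compound 3, cannot be read, since both of its ends sit at that limit. For the measured compounds named here, compound 1 is the only compound with a numerical value, and no single-place step connects it to compound 3.

Compound 4 `C=C1CC[C@H]2[C@@](C)(CC[C@@H](OC(=O)CN)[C@@]2(C)NC=O)[C@@H]1/C=C/C1=CCOC1=O` differs from compound 3 by aminomethyl in place of 4-nitrophenyl on a carbonyl carbon. Going by the values given here, none of the measured steps bears on this exchange: the only step on record is unreadable, and compound 1 differs from compound 3 in more than one place. There is therefore no measured ground to expect a step in either direction beyond the scatter, and the most that can be said is that compound 3 gave no number at all.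

Compound 4 is estimated to give about 40000 nM in this assay, with a range from 8000 nM to 200000 nM. This estimate corresponds to an expected step of an at least 1.2-fold lower number from compound 3 to compound 4 (0.09 log units; that floor lies within the scatter), and a further limit rather than a number is thought quite likely.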

Compound 4, half-maximal inhibitory concentration: > 50000 nM
Compound 4: no number, only a limit; the forecaster's own chance of this, stated with the estimate: 60%; middle value at least 1.2-fold (0.09 log units) away from the limit.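

In this assay compound 4 gives only a limit of the assay, > 50000 nM. The steps to compound 4 from compound 2 and from compound 3 therefore cannot be read, since all three compounds sit at the same limit: the limit of > 50000 nM in this assay, at which 3 of the 4 values shown sit.

The compounds shown leave open how compound 2, compound 3 and compound 4 rank against one another.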